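The compounds below may be only part of what the source reports. "The series", "measured", "known", "first", "only" and "open" are said of these compounds alone.

Notes on the substituent at the aromatic carbon of the shared core, with the rest of the molecule held constant. Compound 1 `Cc1cc(-c2ccc(C=O)cc2)cn2c(CSCCc3ccccc3)cnc12` carries 4-formylphenyl there; in an ADME assay on HEL cells (Homo sapiens) for cytotoxicity, with a stated time of 3 days (a higher number here means that more compound is tolerated, a lower number that less compound is tolerated), compound 1 gives 100 ug/mL. Compound 2 `Cc1cc(N2CCN(C)CC2)cn2c(CSCCc3ccccc3)cnc12` carries 4-methylpiperazin-1-yl; in this assay compound 2 gives 20 ug/mL, which is a 5.0-fold lower number from compound 1 to compound 2 (0.70 log units; beyond the scatter). Compound 3 `Cc1cc(N2CCCC2=O)cn2c(CSCCc3ccccc3)cnc12` carries 2-oxopyrrolidin-1-yl. In this assay compound 3 reaches only a limit, > 100 ug/mL. Among the measured compounds shown here, it is the one value of the three that sits at the limit of > 100 ug/mL in this assay, at which 1 of the 3 values shown sits. Compound 3 thus stands at the top of the shown numbers: an at least 5.0-fold higher number from compound 2 to compound 3 (0.69 log units; beyond the scatter), and against compound 1 there is a number no lower from compound 1 to compound 3 (the limit leaves the size open).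

Compound 4 `Cc1cc(-n2ccc3cccnc32)cn2c(CSCCc3ccccc3)cnc12` differs from compound 3 at this same position: a group of 9 heavy atoms (7 carbon, 2 nitrogen; one five-membered aromatic ring with 1 hetero atom, one six-membered aromatic ring with 1 hetero atom) in place of a group of 6 heavy atoms (4 carbon, 1 nitrogen, 1 oxygen; one five-membered non-aromatic ring with 1 hetero atom), on an aromatic carbon. Both measured exchanges at this carbon bear on the step. Leaving 2-oxopyrrolidin-1-yl for 4-formylphenyl gave no readable change, while leaving it for 4-methylpiperazin-1-yl cost a modest amount. The entering group is, like 4-formylphenyl, aromatic, so compound 4 is expected to land between no change and a modest drop. The expected step is an at least 1.2-fold lower number from compound 3 to compound 4 (0.09 log units; that floor lies within the scatter). Compound 4 is estimated at 80 ug/mL, range 25 ug/mL to 150 ug/mL, with a fair chance that only a limit is reported.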

Compound 4, minimum cytotoxic concentration: 20 ug/mL
For compound 4 the middle estimate is 4.0-fold (0.60 log units) above the measured one; the whole stated range lies above it.
By their numbers in this assay, from the lowest: compounds 2 and 4 (each within the scatter of the next); then compound 1.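

In this assay, an aromatic entering group does not by itself keep the number high at this carbon: there is a 5.0-fold lower number from compound 1 to compound 4 (0.70 log units; beyond the scatter), and an at least 5.0-fold lower number from compound 3 to compound 4 (0.69 log units; beyond the scatter). The group with one five-membered and one six-membered aromatic ring instead reads the same as 4-methylpiperazin-1-yl, with no change at the digits printed from compound 2 to compound 4 (within the scatter), so the low number is now shared by a non-aromatic ring and a fused aromatic one, while 4-formylphenyl, also aromatic, goes against any split by ring type. Compound 3 stands at a limit, so the step from it gives only a floor, and the true distance from 2-oxopyrrolidin-1-yl remains unread: the limit of > 100 ug/mL in this assay, at which 1 of the 4 values shown sits.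

The compounds shown leave open whether the lower number of compound 4 goes with the ring nitrogen of its six-membered ring or with the fused two-ring group as a whole, a question that indol-1-yl, with carbon at that ring atom, or plain phenyl would address. Also open, from the compounds shown here alone, is whether morpholin-4-yl or an open-chain amide would read with 4-methylpiperazin-1-yl or with 2-oxopyrrolidin-1-yl.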